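Swapping Chloro for Methyl on Compound 2

The compounds below may be only part of what the source reports. "The series", "measured", "known", "first", "only" and "open" are said of these compounds alone.

In a functional assay on HL-60 cells (Homo sapiens) for antiproliferative activity, read by MTT assay, with a stated time of 72 h (on this read-out lower numbers stand for stronger inhibition and higher numbers for weaker inhibition), compound 1 (`CCOc1ccc(-c2c(C(=O)c3cc(OC)c(OC)c(OC)c3)sc3ccccc23)cc1`) gives 3500 nM and compound 2 (`COc1cc(C(=O)c2sc3ccccc3c2Nc2ccc(Cl)cc2)cc(OC)c1OC`) gives 5400 nM. These two values lie within the usual scatter of each other, so compound 2 cannot be ranked against compound 1.

Compound 3 (`COc1cc(C(=O)c2sc3ccccc3c2Nc2ccc(C)cc2)cc(OC)c1OC`) has methyl in place of chloro on an aromatic carbon, para to a large group: methyl in place of chloro on an aromatic carbon.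

Among the compounds with values here, the only measured step available is a 1.5-fold higher number from compound 1 to compound 2 (0.19 log units; within the scatter). It swaps 4-ethoxyphenyl for (4-chlorophenyl)amino, so it does not test chloro against methyl. Within the data shown here, no measured pair makes that comparison, and the step expected in this assay is therefore none beyond the scatter, with no clear direction.

The estimated value for compound 3 is 4500 nM, with an expected range of 1800 nM to 11000 nM. This estimate means an expected step of a 1.2-fold lower number from compound 2 to compound 3 (0.08 log units; within the scatter).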

Compound 3, half-maximal inhibitory concentration: 4600 nM
The estimate for compound 3 lay 1.0-fold (0.01 log units) below the measured number; the range from low to high includes it.
By their numbers in this assay, from the lowest: compounds 1, 3 and 2 (each within the scatter of the next).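

Within the data shown here, this is the first direct test of chloro against methyl at this place: in this assay, methyl in place of chloro on the aromatic carbon, para to a large group, gives a 1.2-fold lower number from compound 2 to compound 3 (0.07 log units; within the scatter) and so does not separate the two groups. The swap of the whole substituent reads a 1.3-fold higher number from compound 1 to compound 3 (0.12 log units; within the scatter) and likewise leaves (4-methylphenyl)amino and 4-ethoxyphenyl unranked, just as (4-chlorophenyl)amino was before. No further evidence bears on this result.

The compounds shown leave open whether a group of a different kind at this same place, such as a carboxylic acid or an amine, would move the number beyond the scatter. Going by these compounds, a longer chain such as butyl in place of methyl is equally open.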